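The source may report more compounds than this note shows. Statements on the series, on what has been measured and on what is new or still open speak of the compounds shown alone.

Compound 1 `CCO/C=C(\C#N)C(=O)N/N=C(\C)c1ccc(NS(=O)(=O)c2ccc(Cl)cc2)cc1` and compound 2 `CCOC(=O)c1c(-c2ccco2)c(C#N)c(=O)n(/N=C(\C)c2ccc(NS(=O)(=O)c3ccc(Cl)cc3)cc2)c1N` share the arylsulfonamide hydrazone portion and differ in what the hydrazone nitrogen carries. In a functional assay on HepG2 cells (Homo sapiens) for cytotoxicity, read by sulforhodamine B assay, with a stated time of 48 h (a higher number here means a weaker inhibitor, a lower number a stronger inhibitor), compound 1 gives 16800 nM, and in this assay compound 2 gives 10300 nM. The two numbers lie within the usual scatter of each other, so neither compound can be placed above the other on this evidence; compound 2 simply carries the smaller of the two figures.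

Compound 3 `CCOC(=O)c1c(/C=C/c2ccccc2)c(C#N)c(=O)n(/N=C(\C)c2ccc(NS(=O)(=O)c3ccc(Cl)cc3)cc2)c1N` keeps the whole core of compound 2 and changes one substituent: 2-phenylethenyl in place of furan-2-yl on an aromatic carbon. Among the compounds with values here, no measured pair in this set isolates such an exchange, so there is no step to lean on. With only the two values at hand, the expectation for this change in this assay is a shift of modest size, if any, and not clearly in one direction beyond the scatter. On that basis compound 3 is estimated to give 8000 nM in this assay, with a plausible range from 3000 nM to 25000 nM. The expected step is a 1.3-fold lower number from compound 2 to compound 3 (0.11 log units; within the scatter).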

Compound 3, half-maximal inhibitory concentration: 10700 nM
Estimate against measurement, compound 3: 1.3-fold (0.13 log units) below; low and high end bracket the measured number.
By their numbers in this assay, from the lowest: compounds 2, 3 and 1 (each within the scatter of the next).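

Set on the aromatic carbon opposite the ring nitrogen, ortho to a cyano group and ortho to an ethoxycarbonyl group, 2-phenylethenyl in place of furan-2-yl amounts in this assay to a 1.0-fold higher number from compound 2 to compound 3 (0.02 log units; within the scatter), so the two substituents cannot be told apart on this read-out. Within the data shown here, this is the first pair in the set to isolate a single exchange at this position, and it shows that the position accepts a group of 8 heavy atoms, all carbon, with a double bond outside the aromatic rings, in place of a five-membered aromatic ring with one oxygen and 1 hydrogen-bond acceptor, without the number leaving the scatter. Nothing measured for these compounds bears on why the two groups read alike.

As far as these compounds go, both groups compared carry an aromatic ring, so it remains open whether a methyl group, a longer alkyl chain, an amine or a carboxylic acid on this carbon would read the same. From the compounds shown here alone, it also remains open whether this position can move the number at all in this assay, as one step within the scatter cannot settle that.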